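From Methyl Ester to Acid: Expected Tolerability

A few compounds are considered here, and "the series" means these few. Any claim that something is new, unique, unknown or untested is made for them only; others in the source may bear on it.

Compound 1 `COC(=O)c1ccc(C(=O)NNc2c(Br)cccc2Br)cc1` carries a methoxycarbonyl group on one ring and two bromines on the other. In a toxicity assay on MDCK cells (Canis lupus familiaris) for cytotoxicity, read by CCK-8 assay, with a stated time of 48 h (a lower number here means that less compound is tolerated, a higher number that more compound is tolerated), compound 1 gives 87600 nM. For the measured compounds named here, that is the only plain number among the three compounds measured so far. Compound 2 `CCOc1ccc(C(=O)NNc2c(F)cccc2F)cc1` reaches only the limit of the assay, with > 100000 nM. Compound 3 `CCOc1ccc(C(=O)NNc2cccc(Br)c2)cc1` likewise reaches only the limit, with > 100000 nM. Going by the values given here, the picture is therefore one of broadly tolerated compounds: compound 1 is the one compound with a number, and it sits close to the limit of > 100000 nM in this assay, at which 2 of the 3 values shown sit.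

Compound 4 `O=C(O)c1ccc(C(=O)NNc2c(Br)cccc2Br)cc1` has not yet been measured. Its difference from compound 1 is hydrogen in place of methyl on an oxygen next to a carbonyl group. Among the compounds with values here, no pair of measured compounds differs in exactly this way, so no measured step shows what this change does here. Because compound 1 gives 87600 nM, the expected step in this assay is a 1.4-fold higher number from compound 1 to compound 4 (0.14 log units; within the scatter), within the usual scatter or leaning slightly towards more being tolerated. Compound 4 is thus estimated at 120000 nM, within a range from 50000 nM to 300000 nM, with a fair chance that only a limit is reported.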

Compound 4, half-maximal cytotoxic concentration: > 100000 nM
Compound 4 gave a limit, no number; the forecaster's own chance of this, stated with the estimate: 55%; the middle value lies beyond the limit too.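

For the compounds shown here, compound 4 gives the first measured step for this change, hydrogen in place of methyl on an oxygen next to a carbonyl group, which turns methoxycarbonyl into carboxy. In this assay the change gives an at least 1.1-fold higher number from compound 1 to compound 4 (0.05 log units; that floor lies within the scatter), so the step is only a floor and lies within the scatter; it offers no sign that the carboxy compound is tolerated less well than its methyl ester, but it cannot show a firm gain either. The true size of the step cannot be read because compound 4 gives a limit rather than a number, and the series now crowds at that ceiling: the limit of > 100000 nM in this assay, at which 3 of the 4 values shown sit.

Still open, going by these compounds, is whether other groups in this place, such as a primary amide, an ethyl ester or an amine, would bring the number clearly down from the limit or leave it there. Also open is what the two bromines contribute, since no pair of compounds shown differs only in those atoms, and a step measured at the limit could not fully settle that question.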